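Hydrazonyl ketone series: chloro-to-fluoro swap on the imine nitrogen

A few compounds are considered here, and "the series" means these few. Any claim that something is new, unique, unknown or untested is made for them only; others in the source may bear on it.

Of the compounds shown here, three have been measured in an assay on isolated protein for binding affinity to corticotropin-releasing factor receptor 1 (Homo sapiens); on this read-out lower numbers stand for stronger inhibition and higher numbers for weaker inhibition. Compound 1 `CC(=O)/C(=N\Nc1ccccc1)N(C)c1cccc(Cl)c1` gives only a limit of the assay, > 10000 nM. Compound 2 `CC(=O)/C(=N\Nc1ccccc1)Oc1cccc(Cl)c1` likewise gives only a limit, > 10000 nM. Within the data shown here, compound 3 `CC(=O)/C(=N\c1ccc(Cl)cc1)NNc1ccccc1C` is the one compound with a number, 1830 nM. Among the measured compounds shown here, it stands as the sole measured point; there is no pair of measured compounds differing in a single place, and the shared observation is the limit of > 10000 nM in this assay, at which 2 of the 3 values shown sit.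

Compound 4 `CC(=O)/C(=N\c1cccc(F)c1)NNc1ccccc1C` is not yet measured. It differs from compound 3 by 3-fluorophenyl in place of 4-chlorophenyl on a double-bonded nitrogen; the hydrazine part bearing the methylphenyl group and the acetyl-bearing core are kept unchanged. For the measured compounds named here, no measured step tells how a change on this double-bonded nitrogen moves this assay, and the change replaces both the halogen and the halogen's place on the ring at once.

Going by the values given here, with no step to rest on, the expectation for the move from compound 3 to compound 4 is a 1.9-fold higher number from compound 3 to compound 4 (0.28 log units; within the scatter), a modest loss rather than none, carrying some risk of falling to the limit seen for compound 1 and compound 2. Compound 4 is therefore estimated at 3500 nM, within a range from 1200 nM to 10000 nM.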

Compound 4, inhibition constant: 43 nM
Compound 4: the middle estimate sits 81-fold (1.91 log units) above what was measured, and the stated range ends above it.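

In this assay, among these compounds, the exchange of 4-chlorophenyl for 3-fluorophenyl on a double-bonded nitrogen gives a 43-fold lower number from compound 3 to compound 4 (1.63 log units; beyond the scatter) and is the only readable step so far. This place therefore responds strongly to the aryl group it carries, even though the two groups have the same heavy-atom count, ring type, hydrogen-bond donor and acceptor counts and net charge. The halogen and its place on the ring change together in this single step, and nothing at hand gives a cause for it.

From the compounds shown here alone, whether the change in the number follows the fluorine, its place on the ring or the two together remains open, as does the outcome for a plain phenyl group or a methoxy-bearing phenyl group on the same nitrogen. Going by these compounds, it is also open whether the 3-fluorophenyl group would keep this effect if the methylphenyl group on the hydrazine part gave way to a longer alkyl chain, or if the acetyl group on the core gave way to a carboxylic acid.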